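Series notes: from compound 2 to compound 4

This account rests on a few compounds, and the source may have more. Where it says the series, first, only, none or still open, it means among the compounds named here.

Measured compounds in a functional assay on MGC-803 cells (Homo sapiens) for antiproliferative activity, read by CCK-8 assay, with a stated time of 72 h, tested at 2 uM; on this read-out lower numbers stand for a weaker effect and higher numbers for a stronger effect at the one concentration tested:
compound 1 `Nc1ccccc1NC(=O)c1ccc(CSC(=S)N2CCN(c3ccc(Cl)cc3)CC2)cc1` gives 15%
compound 2 `Nc1ccccc1NC(=O)c1ccc(CSC(=S)N2CCc3cc([N+](=O)[O-])ccc32)cc1` gives 26.8%
compound 3 `Nc1ccccc1NC(=O)c1ccc(CSC(=S)N2CCN(Cc3ccccc3)CC2)cc1` gives 18.1%

Compound 2 stands highest of the three numbers shown. Its gap to compound 3 lies within the scatter, so no order between those two is claimed; its gap to compound 1 lies beyond the scatter. Among the compounds with values here, the single one-place step measured so far, a number 3.1 percentage points higher from compound 1 to compound 3 (within the scatter), alters the group on the ring nitrogen and is itself within the scatter.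

Compound 4 `Nc1ccccc1NC(=O)c1ccc(CSC(=S)N2CCc3ccccc32)cc1` is not yet measured in this assay. It differs from compound 2 by hydrogen in place of nitro on an aromatic carbon. Within the data shown here, no measured step bears on this change: the one step in hand touches a different part of the shared core, and there is no pair that removes a nitro group. Without a guide, the expected step of a number 6.8 percentage points lower from compound 2 to compound 4 (within the scatter) is taken as one within the scatter, drifting toward the middle of the three measured numbers. Compound 4 is therefore estimated at 20% in this assay, with a range from 8% to 33%.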

Compound 4, a percentage reported as inhibition, at one concentration (the size of the read-out at that concentration, not a potency): 44%
Compound 4: the middle estimate sits 24 percentage points below what was measured; the whole stated range lies below it.
By their numbers in this assay, from the lowest: compounds 1, 3 and 2 (each within the scatter of the next, the first and the last beyond it); then compound 4.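

In this assay, within the data shown here, hydrogen in place of nitro on this aromatic carbon gives a number 17.2 percentage points higher from compound 2 to compound 4 (beyond the scatter) and is the first one-place step to lie beyond the scatter. A nitro group at this place, meta to a fused ring and para to a fused ring, is therefore not required for the read-out, and in this pair the compound carrying it has the lower number. No measurement at hand explains this step.

The compounds shown leave open whether an amine, a methoxy group or a chlorine atom on the same aromatic carbon would give a number closer to that of compound 4 or to that of compound 2. Among these compounds, the single pair also leaves open whether the same change would give a step of similar size on a different core.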